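Halogen swap on the benzyl ring: from compound 2 to compound 3

The source may report more compounds than this note shows. Statements on the series, on what has been measured and on what is new or still open speak of the compounds shown alone.

Compound 2 `CC(C)(C)c1cc(/C=C/C(=O)NCCC2CCN(Cc3cccc(Cl)c3)CC2)cc(C(C)(C)C)c1O` is one of two measured members of the series. In an assay on isolated protein for inhibition of Amine oxidase [flavin-containing] A (Homo sapiens), read by fluorescence, with stated times of 15 min and 20 min (on this read-out lower numbers stand for stronger inhibition and higher numbers for weaker inhibition), compound 2 gives 65100 nM. Among the compounds with values here, its only measured neighbour is compound 1 `CC(C)(C)c1cc(/C=C/C(=O)NCCC2CCN(Cc3cccc(F)c3)CC2)cc(C(C)(C)C)c1O`, which in this assay gives 58400 nM; the two numbers lie within the scatter of each other, as a 1.1-fold higher number from compound 1 to compound 2 (0.05 log units; within the scatter) shows. Compound 3 `CC(C)(C)c1cc(/C=C/C(=O)NCCC2CCN(Cc3ccc(Br)cc3)CC2)cc(C(C)(C)C)c1O` is the next member. Its change from compound 2 is 4-bromophenyl in place of 3-chlorophenyl on a saturated chain carbon bound to an amine nitrogen in a ring. Within the data shown here, the only measured step bearing on this is the halogen exchange on the same ring, a 1.1-fold higher number from compound 1 to compound 2 (0.05 log units; within the scatter), which stayed inside the scatter. Among the measured compounds shown here, no step of a halogen moving to a different ring position has been measured. The step of a 1.1-fold lower number from compound 2 to compound 3 (0.04 log units; within the scatter) is therefore expected to lie within the scatter. The estimate for compound 3 in this assay is 60000 nM, with a range from 28000 nM to 130000 nM.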

Compound 3, half-maximal inhibitory concentration: 73200 nM
Compound 3: middle estimate off by 1.2-fold (0.09 log units), on the low side, and the stated range covers the measured number.
By their numbers in this assay, from the lowest: compounds 1, 2 and 3 (each within the scatter of the next).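

In this assay the replacement of 3-chlorophenyl by 4-bromophenyl changes both the halogen and its ring position, and it gives a 1.1-fold higher number from compound 2 to compound 3 (0.05 log units; within the scatter); the replacement of 3-fluorophenyl by 4-bromophenyl gives a 1.3-fold higher number from compound 1 to compound 3 (0.10 log units; within the scatter). On the saturated chain carbon bound to an amine nitrogen in a ring, the read-out therefore does not separate these three halogenated phenyl groups, even when the halogen's ring position differs. No independent data bear on this result.

Both steps change the halogen and its ring position at once, so any separate contributions, including effects that offset each other, remain unresolved; a 4-chlorophenyl group would separate them. Also open, as far as these compounds go, is whether a non-halogen substituent at this place, such as a methoxy group, a nitrile or a carboxylic acid, would move the number beyond the scatter.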